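Swapping the amino group on the imine carbon of compound 2

The source may hold more compounds than are shown below. What is called first, only, known or untested is meant among the compounds shown, and "the series" means these compounds.

Of the compounds shown here, three built on one shared core have been tested in a functional assay on the whole organism with Rattus norvegicus as the target, at a dose of 100 mg/kg; a higher number here means more inhibition at the dose given (going by the name of the read-out), a lower number less inhibition. Compound 1 `CC/N=C(\S)NCCCCCCn1nc(-c2ccccc2)ccc1=O` gives -5.6%. Compound 2 `CN(C)/C(=N/CCCCn1nc(-c2ccccc2)ccc1=O)NC#N` gives 80.7%. Compound 3 `CC/N=C(/NC#N)NCCCCn1nc(-c2ccccc2)ccc1=O` gives 58.8%. Compound 2 thus stands highest of the three, with compound 3 nearest and compound 1 furthest.

Compound 4 `C#CCN/C(=N/CCCCn1nc(-c2ccccc2)ccc1=O)NC#N` has not yet been measured. It differs from compound 2 in one place: propargylamino in place of dimethylamino on a carbon with a double bond to nitrogen. The dimethylamino group on that carbon gives way to a group with one hydrogen-bond donor and a triple bond.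

Going by the values given here, of the measured steps, the one from compound 2 to compound 3 is the closest guide, since it also changes the group at that same position while keeping the same atom count: a number 21.9 percentage points lower from compound 2 to compound 3 (beyond the scatter). The two larger steps, a number 86.3 percentage points higher from compound 1 to compound 2 (beyond the scatter) and a number 64.4 percentage points higher from compound 1 to compound 3 (beyond the scatter), replace a sulfur-containing group and are therefore only indirect evidence. Taken together, they suggest that leaving the dimethylamino group tends to lower the read-out modestly, and a similar step is expected here, a number 20.7 percentage points lower from compound 2 to compound 4 (beyond the scatter), because of the drop seen in a number 21.9 percentage points lower from compound 2 to compound 3 (beyond the scatter).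

Compound 4 is therefore estimated at 60%, with a range from 35% to 85%.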

Compound 4, a percentage reported as inhibition, in the whole organism at one dose (the size of the read-out at that dose, not a potency): -12.9%
The estimate for compound 4 lay 72.9 percentage points above the measured number, outside the stated range (below it).
By their numbers in this assay, from the lowest: compounds 4 and 1 (each within the scatter of the next); then compound 3; then compound 2.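

In this assay, going by these compounds alone, this position proves far more sensitive than the earlier compounds showed: the move to propargylamino gives a number 93.6 percentage points lower from compound 2 to compound 4 (beyond the scatter) and so goes well past a number 21.9 percentage points lower from compound 2 to compound 3 (beyond the scatter) in size. Leaving dimethylamino therefore carries no single modest cost, and the entering group decides the outcome, as compound 3 with its ethylamino group gives 58.8% in this assay while compound 4 with propargylamino gives -12.9% in the same assay. Nothing measured here accounts for this collapse in the read-out, so the change can be described but not explained.

The compounds shown leave open whether the triple bond itself matters, which a propylamino group, the same chain without that bond, would help to settle, and how a methylamino group or a plain amino group would behave on the same carbon. From the compounds shown here alone, it also remains open whether the propargylamino group would give a similar result with a longer chain linking it to the core.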